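The compounds below may be only part of what the source reports. "The series", "measured", "known", "first", "only" and "open" are said of these compounds alone.

Compound 1 `COc1cc(C)cc(-c2c(-c3ccnc(-c4ccc(N(C)C)cc4)c3)cnn2CC#N)c1`: > 100000 nM
Compound 2 `COc1cc(C)cc(-c2nn(CC#N)cc2-c2ccnc(-c3ccc(N(C)C)cc3)c2)c1`: 8900 nM

In a functional assay on SF-268 cells (Homo sapiens) for inhibition, read by sulforhodamine B assay, with a stated time of 48 h (on this read-out higher numbers stand for weaker inhibition of growth and lower numbers for stronger inhibition of growth), compound 1 gives only a limit, > 100000 nM, which is the limit of > 100000 nM in this assay, at which 1 of the 2 values shown sits. Within the data shown here, compound 2 gives 8900 nM, the only number among the two values shown. Compound 3 `Cc1cc(O)cc(-c2nn(CC#N)cc2-c2ccnc(-c3ccc(N(C)C)cc3)c2)c1` differs from compound 2 in one place: hydrogen in place of methyl on an oxygen on an aromatic ring. Among the measured compounds shown here, no measured step covers this change, so in this assay the step is expected to stay within the usual scatter, with no clear direction. Compound 3 is therefore expected to give 10000 nM, in the range 3000 nM to 40000 nM. The estimated step is a 1.1-fold higher number from compound 2 to compound 3 (0.05 log units; within the scatter).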

Compound 3, concentration for total growth inhibition: 16900 nM
Estimate against measurement, compound 3: 1.7-fold (0.23 log units) below; low and high end bracket the measured number.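

In this assay, the change from methoxy to hydroxy on the 3-methoxy-5-methylphenyl group gives a 1.9-fold higher number from compound 2 to compound 3 (0.28 log units; within the scatter) and so stays within the usual scatter. This first reading at this position shows that the values of compound 2 and compound 3 cannot be told apart, so the methyl on that oxygen can be lost without a clear effect on this read-out. Nothing measured here accounts for the size of this step. The compounds shown leave open whether ethoxy on that ring, or an amine in place of the hydroxy, would move the number beyond the scatter.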